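This account rests on a few compounds, and the source may have more. Where it says the series, first, only, none or still open, it means among the compounds named here.

Measured so far in a functional assay on DLD-1 cells (Homo sapiens) for antiproliferative activity, read by MTT assay, with a stated time of 48 h (on this read-out lower numbers stand for stronger inhibition and higher numbers for weaker inhibition), each value a limit of the assay and not a number:

Compound 1 `O=C1/C(=C/c2ccc(F)cc2)CN(C(=S)NC(=O)c2ccccc2)C/C1=C\c1ccc(F)cc1` gives < 10000 nM
Compound 2 `Cc1ccccc1/C=C1\CN(C(=S)NC(=O)c2ccccc2)C/C(=C\c2ccccc2C)C1=O` gives < 10000 nM
Compound 3 `CCCCNC(=S)N1C/C(=C\c2ccccc2F)C(=O)/C(=C/c2ccccc2F)C1` gives < 10000 nM

Compound 2 is known only through its limit, so it cannot be ranked against compound 1 or compound 3. The series offers one shared reading, (the limit of < 10000 nM in this assay, at which 3 of the 3 values shown sit), and no exact value.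

Compound 4 `CCCCNC(=S)N1C/C(=C\c2ccccc2C)C(=O)/C(=C/c2ccccc2C)C1` has not yet been measured. It departs from compound 2 by butyl in place of benzoyl on an amide-type nitrogen. For the measured compounds named here, no measured pair of compounds shows the size of a change like this one. With only the shared limit to go on, no step beyond the scatter is expected in this assay, and no direction is favoured. The expected move is a step that the limit leaves unreadable from compound 2 to compound 4, which remains an estimate. For compound 4 the estimated value is 5000 nM, with an expected range from 1200 nM to 10000 nM.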

Compound 4, half-maximal inhibitory concentration: < 10000 nM
Compound 4: only a limit was reported (the forecaster's own chance of this, stated with the estimate: 50%); the middle value does not contradict the limit.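

Compound 2 and compound 4 are each known in this assay only through a limit of the assay, and no step can be read between them. The compounds shown leave open what exact value any of them has, and whether butyl in place of benzoyl changes it.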